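From cyclobutyl to cyclohexyl against a cytotoxicity limit

The source may hold more compounds than are shown below. What is called first, only, known or untested is meant among the compounds shown, and "the series" means these compounds.

- Compound 1 `COc1cc2cc(C#N)ccc2c(OC)c1Oc1cc(NCCCOC(C)C)nc(Nc2ccc(C#N)cc2)n1`: > 125000 nM
- Compound 2 `COc1cc2cc(C#N)ccc2c(OC)c1Oc1cc(NCC2CC2)nc(Nc2ccc(C#N)cc2)n1`: > 125000 nM
- Compound 3 `COc1cc2cc(C#N)ccc2c(OC)c1Oc1cc(NC2CCC2)nc(Nc2ccc(C#N)cc2)n1`: > 125000 nM

These entries come from an ADME assay on MT4 cells (Homo sapiens) for cytotoxicity, read by MTT assay, with a stated time of 5 days (on this read-out higher numbers stand for lower toxicity in this test and lower numbers for higher toxicity in this test), and each is a limit of the assay rather than a number. Compound 3 gives > 125000 nM, which is a limit. Among the compounds with values here, no rank can be given to compound 3, since the only reading available is the limit of > 125000 nM in this assay, at which 3 of the 3 values shown sit.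

Compound 4 `COc1cc2cc(C#N)ccc2c(OC)c1Oc1cc(NC2CCCCC2)nc(Nc2ccc(C#N)cc2)n1` keeps the shared core and has cyclohexyl in place of cyclobutyl on a nitrogen on an aromatic ring. The closest measured comparison is a step that the two limits leave unreadable from compound 2 to compound 3, and a step that the two limits leave unreadable from compound 1 to compound 3 also bears on it. Within the data shown here, neither has a readable size, so they show only that all three groups on that nitrogen reached the same limit. In this assay, no step beyond the scatter is therefore expected, although a lower number cannot be ruled out. The expected change is an at least 1.0-fold lower number from compound 3 to compound 4 (0.01 log units; that floor lies within the scatter). For compound 4 the estimated value is 120000 nM, within an expected range from 50000 nM to 200000 nM.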

Compound 4, half-maximal cytotoxic concentration: > 125000 nM
Compound 4: no number, only a limit; the forecaster's own chance of this, stated with the estimate: 65%; middle value at least 1.0-fold (0.01 log units) from the limit.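

No step can be read between compound 4 and compounds 1, 2 and 3, since all four results are limits rather than numbers: the limit of > 125000 nM in this assay, at which 4 of the 4 values shown sit.

The compounds shown leave open whether these groups on the nitrogen differ at all in cytotoxicity, and at what concentration any of the four reaches its half-maximal cytotoxic effect.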